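This account rests on a few compounds, and the source may have more. Where it says the series, first, only, none or still open, it means among the compounds named here.

Measured so far:
compound 1 `CCCNC(=O)c1ccc(Oc2nc(-c3c(C)noc3C)cnc2N)cc1` gives 17500 nM
compound 2 `Cc1noc(C)c1-c1cnc(N)c(Oc2ccc(C(=O)Nc3ccccc3Cl)cc2)n1` gives > 100000 nM; this is a limit of the assay, not a number
compound 3 `Cn1cc(-c2cnc(N)c(Oc3ccc(C(=O)Nc4ccccc4Cl)cc3)n2)cn1` gives 41400 nM

In a functional assay on LoVo cells (Homo sapiens) for inhibition, read by MTT assay, with a stated time of 72 h (on this read-out higher numbers stand for weaker inhibition and lower numbers for stronger inhibition), compound 3 stands highest of the two numbers available; compound 1 lies below it, and the value of compound 2 is a limit only (the limit of > 100000 nM in this assay, at which 1 of the 3 values shown sits). The steps recorded so far are an at least 5.7-fold higher number from compound 1 to compound 2 (0.75 log units; beyond the scatter) and an at least 2.4-fold lower number from compound 2 to compound 3 (0.38 log units; beyond the scatter). Compound 4 `Cn1cc(-c2cnc(N)c(Oc3ccc(C(=O)Nc4ncccc4Cl)cc3)n2)cn1` differs from compound 3 by 3-chloropyridin-2-yl in place of 2-chlorophenyl on an amide-type nitrogen. Neither measured step touches this kind of exchange on the amide nitrogen: the first changed propyl for an aryl group, the second changed the heteroaryl on the core. Among the compounds with values here, no step therefore bears on it directly, and no movement beyond the scatter is expected in this assay; the step from compound 3 to compound 4 is estimated at a 1.2-fold lower number from compound 3 to compound 4 (0.07 log units; within the scatter). Compound 4 is expected to give about 35000 nM, within 12000 nM to 100000 nM.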

Compound 4, half-maximal inhibitory concentration: 16500 nM
Estimate against measurement, compound 4: 2.1-fold (0.33 log units) above, within the range that was stated.
By their numbers in this assay, from the lowest: compounds 4 and 1 (each within the scatter of the next); then compound 3. At a limit, above all of these: compound 2.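

In this assay the group on the amide-type nitrogen responds to a change inside the aromatic ring itself, with the chlorine kept: 3-chloropyridin-2-yl in place of 2-chlorophenyl gives a 2.5-fold lower number from compound 3 to compound 4 (0.40 log units; beyond the scatter). The earlier step at this nitrogen compared only propyl with an aryl group, so this is the first comparison shown between two aryl groups there. No measurement shown accounts for this step.

As far as these compounds go, it remains open whether the step holds with 3,5-dimethyl-1,2-oxazol-4-yl on the core. From the compounds shown here alone, the effect of an unsubstituted pyridin-2-yl on the amide-type nitrogen also remains open.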